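Two Coumarin Analogues and an Untested Third

The compounds below may be only part of what the source reports. "The series", "measured", "known", "first", "only" and "open" are said of these compounds alone.

Two compounds from the same series share a core and differ in the groups hanging from it. Compound 1 `Cc1c(Cc2ccccc2)c(=O)oc2cc(OCC(O)CNCc3cccs3)ccc12` and compound 2 `Cc1c(Cc2cccc(F)c2)c(=O)oc2cc(OCC(O)CN3CCC(C(N)=O)CC3)ccc12` were both tested in an ADME assay on A549 cells (Homo sapiens) for cytotoxicity, read by CellTiter-Glo; a higher number here means that more compound is tolerated, a lower number that less compound is tolerated. In this assay compound 1 gives 87300 nM, and compound 2 gives 53300 nM. Since these two numbers lie within the usual scatter of repeated measurements, they cannot be told apart with confidence, and compound 2 can only be said to sit alongside compound 1.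

Compound 3 `COc1ccc(Cc2c(C)c3ccc(OCC(O)CN4CCC(C(N)=O)CC4)cc3oc2=O)c(Br)c1` has not yet been measured. It is built from compound 2 by one change: 2-bromo-4-methoxyphenyl in place of 3-fluorophenyl on a saturated chain carbon bound to an aromatic carbon. Among the compounds with values here, no measured pair in this set shows what such a swap does to the read-out, so the expectation rests on the two values at hand alone. Because compound 2 gives 53300 nM in this assay, the step from compound 2 to compound 3 is expected to be small, a 1.3-fold lower number from compound 2 to compound 3 (0.12 log units; within the scatter), and to stay close to the scatter. Compound 3 is therefore estimated at 40000 nM, with a plausible range from 15000 nM to 100000 nM.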

Compound 3, half-maximal cytotoxic concentration: 44400 nM
For compound 3 the middle estimate is 1.1-fold (0.05 log units) below the measured one; the measured number falls inside the stated range.
By their numbers in this assay, from the lowest: compounds 3, 2 and 1 (each within the scatter of the next).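

Within the data shown here, this is the first pair in the set that differs in only one place, so the change on a saturated chain carbon bound to an aromatic carbon can now be read directly: in (this assay), 2-bromo-4-methoxyphenyl in place of 3-fluorophenyl gives (a 1.2-fold lower number from compound 2 to compound 3 (0.08 log units; within the scatter)). The entering group has 9 heavy atoms against 7 and brings a bromine and a hydrogen-bond acceptor that the leaving group lacks, yet compound 2 and compound 3 cannot be told apart in this read-out, so this particular swap leaves no measurable mark on tolerated concentration. No measurement shown here offers an explanation for this result.

Among these compounds, the bromine and the methoxy group enter together, so the share of each cannot be separated, and compound 1 differs from compound 2 in more than one place, so no step involving compound 1 can be read. From the compounds shown here alone, it also remains open whether an amine or a carboxylic acid on this phenyl ring, or a longer chain in place of the single carbon linking it to the shared core, would shift the number beyond the scatter.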